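The source may report more compounds than this note shows. Statements on the series, on what has been measured and on what is new or still open speak of the compounds shown alone.

In a functional assay on SMMC-7721 cells (Homo sapiens) for inhibition, read by MTT assay, with a stated time of 48 h (on this read-out lower numbers stand for stronger inhibition and higher numbers for weaker inhibition), compound 1 `O=C(Nc1ccccn1)Nc1cc(-c2cncnc2)ccc1OC(F)(F)F` gives 21600 nM. Within the data shown here, this is the only number available, since in this assay compound 2 `COc1ccc(-c2cc(NC(=O)Nc3ccncc3)cc(OC)c2OC)cn1` stands as "not determined" (no result reported). Among the measured compounds shown here, compound 1 therefore cannot be ranked against any other compound, and no step between measured compounds is available as a guide.

The next compound, compound 3 `O=C(Nc1nccs1)Nc1cc(-c2cncnc2)ccc1OC(F)(F)F`, keeps the core of compound 1 and differs in one place: 1,3-thiazol-2-yl in place of pyridin-2-yl on an amide-type nitrogen. In words, 1,3-thiazol-2-yl stands in place of pyridin-2-yl on an amide-type nitrogen, so a five-membered aromatic ring replaces a six-membered one at that site.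

For the measured compounds named here, with no measured precedent for this exchange, the expectation is for no change beyond the scatter in this assay, with only a slight and tentative lean toward stronger inhibition. Going by the values given here, the expected step of a 1.4-fold lower number from compound 1 to compound 3 (0.13 log units; within the scatter) is accordingly small, and the wide range reflects how little the single measured value of compound 1, 21600 nM, can support. For compound 3 the estimate is 16000 nM, with an expected range from 5000 nM to 50000 nM.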

Compound 3, half-maximal inhibitory concentration: 9350 nM
Compound 3: middle estimate off by 1.7-fold (0.23 log units), on the high side, within the range that was stated.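

Among these compounds, the exchange of pyridin-2-yl for 1,3-thiazol-2-yl on an amide-type nitrogen gives the first measured step: in this assay it comes with a 2.3-fold lower number from compound 1 to compound 3 (0.36 log units; beyond the scatter), which is modest but beyond the usual scatter. This shows that the read-out responds to the group at this site, and that a five-membered aromatic ring with two hetero atoms is accepted there in place of a six-membered one with a single hetero atom, with compound 3 reading 9350 nM and no loss of inhibition. Nothing available explains why the number falls, and no independent measurement bears on this result.

Among the compounds shown here, because ring size, sulfur and the number of hetero atoms all change in this one exchange, the single step cannot show which of them goes with the lower number, and one pair establishes no trend. As far as these compounds go, it also remains open how the read-out would respond if that same amide-type nitrogen carried a non-aromatic group instead, such as a butyl chain, a cyclohexyl ring or a chain ending in a carboxylic acid.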